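From 4-(methylsulfonyl)phenyl to 5-(methylcarbamoyl)pyrazin-2-yl

This account rests on a few compounds, and the source may have more. Where it says the series, first, only, none or still open, it means among the compounds named here.

For the measured compounds named here, in an ADME assay on MDCKII-LE cells (Canis lupus familiaris) for permeability (a higher number here means that the compound crosses the layer faster, a lower number that the compound crosses the layer more slowly), two compounds with a shared core have numbers so far: compound 1 `Cc1cnc(NC(=O)c2cc(Oc3cnc(C(=O)N(C)C)nc3)c3cc(C)oc3c2)cn1` at 20.1 10^-6 cm/s and compound 2 `Cc1cnc(NC(=O)c2cc(Oc3ccc(S(C)(=O)=O)cc3)c3cc(C)oc3c2)cn1` at 7.6 10^-6 cm/s as the lower of the two. The gap between them lies beyond the scatter. Compound 3 `CNC(=O)c1cnc(Oc2cc(C(=O)Nc3cnc(C)cn3)cc3oc(C)cc23)cn1` is still unmeasured. Going by the values given here, it carries 5-(methylcarbamoyl)pyrazin-2-yl in place of 4-(methylsulfonyl)phenyl on an oxygen on an aromatic ring and no measured pair isolates this change. With compound 2 at 7.6 10^-6 cm/s and compound 1 at 20.1 10^-6 cm/s as the only reference points, a small rise in this assay is expected that stays within the scatter. The expected move is a 1.2-fold higher number from compound 2 to compound 3 (0.07 log units; within the scatter) and the estimate remains loose. For compound 3 the estimated value is 9 10^-6 cm/s with an expected range from 4 10^-6 cm/s to 18 10^-6 cm/s for now.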

Compound 3, apparent permeability: 20.9 10^-6 cm/s
For compound 3 the middle estimate is 2.3-fold (0.37 log units) below the measured one, outside the stated range (above it).
By their numbers in this assay, from the lowest: compound 2; then compounds 1 and 3 (each within the scatter of the next).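

On the oxygen on an aromatic ring, this assay now has its first single-place reading: 5-(methylcarbamoyl)pyrazin-2-yl in place of 4-(methylsulfonyl)phenyl gives a 2.8-fold higher number from compound 2 to compound 3 (0.44 log units; beyond the scatter). This step comes with an entering group that counts 1 hydrogen-bond donor against 0 for the leaving group, and compound 3 stands within the scatter of compound 1, so two different groups at this place share the upper level of the series. No measurement on hand bears on what lies behind the step.

The compounds shown do not separate the contribution of the ring from that of its substituent. A phenyl ring carrying methylcarbamoyl, or a pyrazin-2-yl ring carrying a carboxylic acid or an amine, would put that question to the test.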